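Cytotoxicity of Three Measured Compounds and One Unmeasured

The source may report more compounds than this note shows. Statements on the series, on what has been measured and on what is new or still open speak of the compounds shown alone.

Compound 1 `CN1Cc2ccc(OCc3ccccc3)cc2[C@@H](O)C1` was tested in an ADME assay on Vero cells (Chlorocebus sabaeus) for cytotoxicity, read by sulforhodamine B assay, with a stated time of 72 h; a higher number here means a weaker inhibitor, a lower number a stronger inhibitor. In this assay compound 1 gives only a limit of the assay, > 100000 nM, not a number. Compound 2 `CN1Cc2ccc(OCCC3CCCCC3)cc2[C@@H](O)C1` differs from compound 1 by one change: cyclohexylmethyl in place of phenyl on a saturated chain carbon bound to an oxygen on an aromatic ring. In this assay compound 2 likewise gives only a limit, > 50000 nM. The two limits leave the step that the two limits leave unreadable from compound 1 to compound 2 unreadable in size. Compound 3 `CN1Cc2c(OCc3ccccc3)cccc2[C@@H](O)C1` is built from the same atoms as compound 1, joined differently; the difference between the two cores is not broken down here. In this assay compound 3 also gives only a limit, > 100000 nM. Compound 4 `CN1Cc2c(OCCC3CCCCC3)cccc2[C@@H](O)C1` has not yet been measured and carries the same change relative to compound 3 as compound 2 does relative to compound 1: cyclohexylmethyl in place of phenyl on a saturated chain carbon bound to an oxygen on an aromatic ring. The expected step is a step that the limit leaves unreadable from compound 3 to compound 4, resting on compound 3 sitting at the limit of > 100000 nM in this assay, at which 2 of the 3 values shown sit, and on the unreadable step that the two limits leave unreadable from compound 1 to compound 2. Compound 4 is therefore expected to give about 150000 nM in this assay, most likely again reported only as a limit.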

Compound 4, half-maximal inhibitory concentration: 62700 nM
Compound 4: middle estimate off by 2.4-fold (0.38 log units), on the high side, within the range that was stated.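

In this assay, going by these compounds alone, cyclohexylmethyl in place of phenyl on the core of compound 3 gives an at least 1.5-fold lower number from compound 3 to compound 4 (0.20 log units; that floor lies within the scatter), so the only firm reading is a floor that does not clear the usual scatter. Going by these compounds, the true size of the step stays unknown because compound 3 gives only a limit of the assay, not a number: the limit of > 100000 nM in this assay, at which 2 of the 4 values shown sit. The same change on the core of compound 1 cannot be read at all, so nothing here shows that the step carries from one core to the other, and nothing shows that it fails to.

The compounds shown leave open whether the ring or the added carbon counts for more in this assay, as the two always change together here. They also leave open how either core would read with a longer chain, or with an amine or a carboxylic acid on the end of the chain.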